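This account rests on a few compounds, and the source may have more. Where it says the series, first, only, none or still open, it means among the compounds named here.

Compounds measured so far:
compound 1, `O=C(Nc1cccc(-n2cc(-c3ccncc3)c(-c3ccc(Cl)c(O)c3)n2)c1)Nc1cccc(C(F)(F)F)c1`: > 32500 nM
compound 2, `COc1cc(-c2nn(-c3cccc(NC(=O)c4cccc(C(F)(F)F)c4)c3)cc2-c2ccncc2)ccc1Cl`: > 50000 nM
compound 3, `O=C(Nc1cccc(-n2cc(-c3ccncc3)c(-c3ccc(Cl)c(O)c3)n2)c1)Nc1cc(C(F)(F)F)cc(C(F)(F)F)c1`: 12800 nM

In a functional assay on NCI-H522 cells (Homo sapiens) for inhibition, read by sulforhodamine B assay, with a stated time of 48 h (a lower number here means that less compound is tolerated, a higher number that more compound is tolerated), compound 2 gives only a limit, > 50000 nM; this is the limit of > 50000 nM in this assay, at which 1 of the 3 values shown sits, the higher of the two limits in the set. Compound 1 likewise sits at a limit, > 32500 nM. Only compound 3 gives a number, 12800 nM.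

Compound 4, `COc1cc(-c2nn(-c3cccc(NC(=O)c4ccccc4)c3)cc2-c2ccncc2)ccc1Cl`, differs from compound 2 in one place: hydrogen in place of trifluoromethyl on an aromatic carbon. For the measured compounds named here, the one measured step that bears on it runs the other way: an at least 2.5-fold lower number from compound 1 to compound 3 (0.40 log units; beyond the scatter). Removing the trifluoromethyl is therefore not expected to lower the number; if anything a higher number or no change beyond the scatter is expected in this assay, so compound 4 is expected to stay at a limit, a step that the limit leaves unreadable from compound 2 to compound 4, with an estimate of 60000 nM (30000 nM to 150000 nM).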

Compound 4, concentration lethal to 50% of the cells: > 100000 nM
Compound 4: only a limit was reported; the forecaster's own chance of this, stated with the estimate: 85%; middle value at least 1.6-fold (0.22 log units) from the limit.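

Compound 2 and compound 4 both give only limits in this assay, so the step between them cannot be read. From the compounds shown here alone, whether hydrogen in place of trifluoromethyl changes the number in this pair remains open.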